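Longer alkyl chains and inhibition on murine leukemia cells

The source may hold more compounds than are shown below. What is called first, only, known or untested is meant among the compounds shown, and "the series" means these compounds.

Measured compounds:
compound 1, `CCCCCCCCc1cn([C@H]2C[C@@H]3OP(=O)(O)OC[C@H]3O2)c(=O)[nH]c1=O`: 164 ug/mL
compound 2, `CCCc1cn([C@H]2C[C@@H]3OP(=O)(O)OC[C@H]3O2)c(=O)[nH]c1=O`: > 500 ug/mL

In a functional assay on L1210 cells (Mus musculus) (a higher number here means a weaker inhibitor, a lower number a stronger inhibitor), compound 1 gives 164 ug/mL. For compound 2 the result is only a limit of this assay, > 500 ug/mL, so its true value is not known (the limit of > 500 ug/mL in this assay, at which 1 of the 2 values shown sits). Compound 3, `CCCCCc1cn([C@H]2C[C@@H]3OP(=O)(O)OC[C@H]3O2)c(=O)[nH]c1=O`, differs from compound 2 by ethyl in place of hydrogen on a saturated chain carbon, three bonds along the chain from an aromatic carbon. Among the measured compounds shown here, the one measured step that bears on this, an at least 3.0-fold higher number from compound 1 to compound 2 (0.48 log units; beyond the scatter), runs the opposite way and shows that shortening the chain weakens inhibition. Lengthening it again in compound 3 is therefore expected to lower the number, an at least 1.2-fold lower number from compound 2 to compound 3 (0.09 log units; that floor lies within the scatter), though the limit on compound 2 makes the size uncertain. Compound 3 is thus estimated at 400 ug/mL, within 150 ug/mL to 1000 ug/mL.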

Compound 3, concentration for 50% inhibition: > 500 ug/mL
Compound 3 ended at the assay's limit; the forecaster's own chance of this, stated with the estimate: 45%; middle value at least 1.2-fold (0.09 log units) from the limit.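

In this assay, ethyl in place of hydrogen on this saturated chain carbon, three bonds along the chain from an aromatic carbon, does not yield a readable value: compound 3 gives > 500 ug/mL, which is a limit. Among the compounds shown here, the one readable comparison is an at least 3.0-fold higher number from compound 1 to compound 3 (0.48 log units; beyond the scatter), so hydrogen in place of propyl, five bonds along the chain from an aromatic carbon, already weakens inhibition. The step between the two limits cannot be read: the limit of > 500 ug/mL in this assay, at which 2 of the 3 values shown sit.

As far as these compounds go, the true values of the two shorter-chain compounds remain open. So does whether a chain longer than that of compound 1, or an amine at its end, would lower the number further.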